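The source may hold more compounds than are shown below. What is called first, only, known or untested is meant among the compounds shown, and "the series" means these compounds.

Measured compounds:
compound 1 `O=C(O)Cc1sc(C(c2ccc(F)cc2)c2ccc(F)cc2)nc1-c1ccnc(N2CCC2)c1`, 660 nM
compound 2 `O=C(O)Cc1sc(C(c2ccccc2)c2ccccc2)nc1-c1ccc(C(F)(F)F)cc1`, 1100 nM

Of the compounds shown here, two have been measured in an in vitro assay on HEK385-7 cells for displacement of a labelled ligand from prostaglandin D2 receptor 2 (Homo sapiens); a lower number here means a stronger inhibitor, a higher number a weaker inhibitor. Compound 1 gives 660 nM, and compound 2 gives 1100 nM; the two numbers lie within the usual scatter of each other, so neither compound can be set apart from the other on these data, and compound 1 simply stands at one end of a pair that cannot be told apart.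

Compound 3 `O=C(O)Cc1sc(C(c2ccc(F)cc2)c2ccc(F)cc2)nc1-c1ccnc(Cl)c1` has not yet been measured. It differs from compound 1 in one place: chloro in place of azetidin-1-yl on an aromatic carbon. For the measured compounds named here, no step between measured compounds of this kind has been recorded, so nothing measured here speaks to the size or direction of this change. The expectation is that the step of a 1.4-fold higher number from compound 1 to compound 3 (0.13 log units; within the scatter) will be small and not clearly beyond the scatter. Compound 3 is therefore estimated at 900 nM, with a range from 350 nM to 2500 nM.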

Compound 3, half-maximal inhibitory concentration: 3.1 nM
Beside the measured number, compound 3's estimate is 290-fold (2.46 log units) above it; measured number below the stated range.
By their numbers in this assay, from the lowest: compound 3; then compounds 1 and 2 (each within the scatter of the next).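

In this assay, putting chloro in place of azetidin-1-yl on the aromatic carbon next to the ring nitrogen gives a 210-fold lower number from compound 1 to compound 3 (2.33 log units; beyond the scatter), a large step beyond the scatter. For the compounds shown here, compounds 1 and 2 differ in more than one place and could not be told apart, so this is the first sign that this position can move the number strongly with the rest of compound 1 held fixed. Nothing available here bears on why this single change has so large an effect.

The compounds shown leave open whether the step follows from the arrival of chloro or the departure of azetidin-1-yl. They also do not show how a hydrogen, a methyl, a methoxy or dimethylamino would read at this position, or whether a bromo would behave like chloro.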